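Carbamate, amide and urea variants: Vero cell cytotoxicity

This account rests on a few compounds, and the source may have more. Where it says the series, first, only, none or still open, it means among the compounds named here.

Compound 1 `CCOCCOC(=O)Nc1cc2nc(C3CCCCC3)[nH]c2cc1N(C)C`. In an ADME assay on Vero cells (Chlorocebus sabaeus) for cytotoxicity, read by resazurin assay, with a stated time of 3 days (a lower number here means a stronger inhibitor, a higher number a weaker inhibitor), compound 1 gives > 100 ug/mL, a limit of the assay.
Compound 2 `CN(C)c1cc2[nH]c(C3CCCCC3)nc2cc1NC(=O)c1ccccc1`. In this assay compound 2 gives > 100 ug/mL, again a limit of the assay and not a number.

Compound 2 therefore stands only at the top of the readable range in this assay, and it shares this position with the limit of > 100 ug/mL in this assay, at which 2 of the 2 values shown sit. Among the compounds with values here, the single measured step, a step that the two limits leave unreadable from compound 1 to compound 2, runs between two limits and its size cannot be read.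

Compound 3 `CCCCNC(=O)Nc1cc2nc(C3CCCCC3)[nH]c2cc1N(C)C` is not yet measured. It differs from compound 2 by butylamino in place of phenyl on a carbonyl carbon. Within the data shown here, no measured step gives a readable size for a change at this carbonyl carbon; the only comparison available ends at the limit on both sides. On that basis the step from compound 2 is expected to stay within the scatter, so compound 3 is expected to remain at or near the limit, with a step that the limit leaves unreadable from compound 2 to compound 3 as the expected shift. For compound 3 the estimate in this assay is 150 ug/mL, expected to fall between 50 ug/mL and 400 ug/mL, most likely reported only as a limit.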

Compound 3, half-maximal inhibitory concentration: > 100 ug/mL
Compound 3 gave a limit, no number (the forecaster's own chance of this, stated with the estimate: 80%); the middle value lies beyond the limit too.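

In this assay compound 3 gives > 100 ug/mL, a limit of the assay and not a number. No step among compound 1, compound 2 and compound 3 can be read, as all three sit at the same limit: the limit of > 100 ug/mL in this assay, at which 3 of the 3 values shown sit.

The compounds shown leave open whether any group on this carbonyl carbon would give a readable value in this assay.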